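A larger group on the nitrogen of compound 2

The compounds below may be only part of what the source reports. "The series", "measured", "known", "first", "only" and "open" are said of these compounds alone.

Compound 1 `Nc1ccc(/N=N/c2ccc(-c3nc4ncccc4[nH]3)cc2)cc1` gives 1830 nM
Compound 2 `Nc1ccc(-c2nc3ncccc3[nH]2)cc1` gives 3060 nM

In a functional assay on HCT-116 cells (Homo sapiens) for antiproliferative activity, read by MTT assay, with a stated time of 48 h (a higher number here means a weaker inhibitor, a lower number a stronger inhibitor), compound 2 reads 3060 nM and compound 1 reads 1830 nM on the same scale. These two numbers lie within the usual scatter of repeated measurements, so neither compound can be ranked over the other.

Compound 3 `CC(=O)C(=NNc1ccc(-c2nc3ncccc3[nH]2)cc1)C(C)=O` has not yet been measured. It keeps the structure of compound 2 except in one place, where a hydrogen atom on a nitrogen on an aromatic ring gives way to a larger group with no ring. The change reads a group of 8 heavy atoms (5 carbon, 1 nitrogen, 2 oxygen; no ring) in place of a hydrogen atom, on a nitrogen on an aromatic ring and it is the only one.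

For the measured compounds named here, no measured pair here differs in just one place, so any forecast is loose. Going by the values given here, compound 1 at 1830 nM is the only other reading, and its closeness to compound 2 gives no reason to expect a large shift. The expected result is a small move to a lower number and nothing beyond the scatter, with a 1.5-fold lower number from compound 2 to compound 3 (0.18 log units; within the scatter) as the estimated step in this assay for now. For compound 3 the estimated value is 2000 nM with an expected range of 600 nM to 7000 nM in most repeat measurements.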

Compound 3, half-maximal inhibitory concentration: 1690 nM
The estimate for compound 3 lay 1.2-fold (0.07 log units) above the measured number; the range from low to high includes it.
By their numbers in this assay, from the lowest: compounds 3, 1 and 2 (each within the scatter of the next).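

In this assay, replacing a hydrogen atom on the nitrogen with a group of 8 heavy atoms gives a 1.8-fold lower number from compound 2 to compound 3 (0.26 log units; within the scatter). For the compounds shown here, this is the first pair here that differs in only one place, so it is the first direct look at this position: the nitrogen on an aromatic ring can carry this much larger group, with no ring and 3 double bonds outside aromatic rings, and the reading stays within the scatter of the one for the hydrogen atom. The two compounds therefore cannot be ranked, and nothing here gives a measured reason why so large a change leaves the number so close.

A single step at a single position cannot show whether this holds for other groups on the same nitrogen, such as a small methyl group, a phenyl ring or a longer alkyl chain. It also leaves open which part of the new group matters, if any does, and a version with one of its two carbonyl groups removed would begin to answer that.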